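This account rests on a few compounds, and the source may have more. Where it says the series, first, only, none or still open, it means among the compounds named here.

Compound 1 `COc1ccc(CN(C(=O)CSc2nc3ccccc3s2)c2cc(OC)c(OC)c(OC)c2)cc1F` gives 416 nM in a functional assay on MGC-803 cells (Homo sapiens) for antiproliferative activity, read by MTT assay, with a stated time of 48 h; on this read-out lower numbers stand for stronger inhibition and higher numbers for weaker inhibition. Compound 3 `COc1ccc(CN(C(=O)CSc2nc3ccccc3s2)c2cc(OC)c(OC)c(OC)c2)cc1[N+](=O)[O-]` gives 682 nM. Compound 2 `COc1cc(N(Cc2ccc(F)cc2)C(=O)CSc2nc3ccccc3s2)cc(OC)c1OC` reaches only the assay limit, > 80000 nM.

Among the compounds with values here, compound 2 thus stands at the limit (the limit of > 80000 nM in this assay, at which 1 of the 3 values shown sits), the one value of the three that is not a number. Compound 4 `COc1cc(N(Cc2ccc(Cl)cc2)C(=O)CSc2nc3ccccc3s2)cc(OC)c1OC` differs from it by chloro in place of fluoro on an aromatic carbon. Within the data shown here, no measured step covers this swap directly: an at least 190-fold higher number from compound 1 to compound 2 (2.28 log units; beyond the scatter) and an at least 110-fold lower number from compound 2 to compound 3 (2.06 log units; beyond the scatter) each exchange the whole 4-fluorophenyl for a differently substituted ring, while a 1.6-fold higher number from compound 1 to compound 3 (0.21 log units; within the scatter) lies within the scatter. Nothing measured here shows a change of halogen alone moving the number, so compound 4 is expected to stay near the limit, with an at least 1.1-fold lower number from compound 2 to compound 4 (0.05 log units; that floor lies within the scatter) as the anticipated step. The estimated value for compound 4 is 70000 nM, in a range from 8000 nM to 400000 nM.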

Compound 4, half-maximal inhibitory concentration: > 80000 nM
Compound 4: a limit, no number (the forecaster's own chance of this, stated with the estimate: 60%); middle value at least 1.1-fold (0.05 log units) away from the limit.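

The step from fluoro to chloro cannot be read, as compound 2 and compound 4 are both limits and not numbers. With chloro as with fluoro as the only ring substituent, the benzyl compounds give no number, and the distance to the methoxy-bearing rings stays large, with an at least 110-fold higher number from compound 3 to compound 4 (2.06 log units; beyond the scatter) and an at least 190-fold higher number from compound 1 to compound 4 (2.28 log units; beyond the scatter). Two halogens now share this ceiling: the limit of > 80000 nM in this assay, at which 2 of the 4 values shown sit.

Open, as far as these compounds go, is whether a methoxy group alone on this ring, as in 4-methoxyphenyl, suffices for a measurable value. Also open, from the compounds shown here alone, is how far an amine in place of chloro would move the result.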